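The source may hold more compounds than are shown below. What is called first, only, known or untested is meant among the compounds shown, and "the series" means these compounds.

In a functional assay on PC-3 cells (Homo sapiens) for inhibition, read by MTT assay (a higher number here means a weaker inhibitor, a lower number a stronger inhibitor), compound 1 `COc1c(N2CCN(C)CC2)c(F)cc2c(=O)c(C(=O)N/N=C\c3ccc([N+](=O)[O-])cc3)cn(C3CC3)c12` gives 15 ug/mL, compound 2 `COc1cc(/C=N\NC(=O)c2cn(C3CC3)c3c(OC)c(N4CCN(C)CC4)c(F)cc3c2=O)cc(OC)c1OC` gives 8.5 ug/mL and compound 3 `COc1c(N2CCN(C)CC2)c(F)cc2c(=O)c(C(=O)N/N=C\c3ccc(O)cc3)cn(C3CC3)c12` gives 14.4 ug/mL. Compound 3 therefore lies within the scatter of both other compounds. Compound 4 `COc1c(N2CCN(C)CC2)c(F)cc2c(=O)c(C(=O)N/N=C\c3cccc(C)c3)cn(C3CC3)c12` has 3-methylphenyl in place of 4-hydroxyphenyl on a carbon with a double bond to nitrogen. Going by the values given here, two measured steps bear on this change: a 1.0-fold lower number from compound 1 to compound 3 (0.02 log units; within the scatter) and a 1.7-fold higher number from compound 2 to compound 3 (0.23 log units; within the scatter). Both exchange the group at this same place, and neither leaves the scatter, although the groups exchanged differ widely. No step beyond the scatter is therefore expected, and the estimated step is a 1.1-fold lower number from compound 3 to compound 4 (0.04 log units; within the scatter). Compound 4 is expected at 13 ug/mL, with an estimated range from 6.5 ug/mL to 26 ug/mL.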

Compound 4, half-maximal inhibitory concentration: 10 ug/mL
Compound 4: middle estimate off by 1.3-fold (0.11 log units), on the high side; measured number inside the range.
By their numbers in this assay, from the lowest: compounds 2, 4, 3 and 1 (each within the scatter of the next).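

In this assay, the 3-methylphenyl group stays within the scatter of all three earlier groups at this place (a 1.4-fold lower number from compound 3 to compound 4 (0.16 log units; within the scatter); a 1.2-fold higher number from compound 2 to compound 4 (0.07 log units; within the scatter); a 1.5-fold lower number from compound 1 to compound 4 (0.18 log units; within the scatter)). The hydrogen-bond donor and acceptor of 4-hydroxyphenyl can therefore be lost on this carbon with a double bond to nitrogen without a step beyond the scatter, and the same holds for the exchange of 4-nitrophenyl or 3,4,5-trimethoxyphenyl for a ring of carbon and a methyl alone. On these data alone, whether an amine, a carboxylic acid or a longer alkyl chain at this place would step beyond the scatter stays open. Nothing available gives a reason for these small steps.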